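Trifluoromethyl in Place of Cyclopropylmethoxy on the Aryl Ring

The source may hold more compounds than are shown below. What is called first, only, known or untested is meant among the compounds shown, and "the series" means these compounds.

Compound 1 `COc1ccccc1N1CCN(CCCNc2nc(C)cc(C)c2C(N)=O)CC1`: 39.8 nM
Compound 2 `COc1ccccc1N1CCN(CCCNc2cncnc2C(=O)N(C)C)CC1`: 50.1 nM
Compound 3 `CN(C)C(=O)c1cccnc1NCCCN1CCN(c2ccccc2OCC2CC2)CC1`: 10 nM

Of the compounds shown here, three have been measured in a functional assay on aorta for antagonist activity at Alpha-1D adrenergic receptor (Rattus norvegicus); a higher number here means weaker binding, a lower number tighter binding. Compound 3 gives the lowest number of the three, at 10 nM; compound 1 lies above it by a gap beyond the scatter, and compound 2 further still. The step under study leads from compound 3 to compound 4 `CN(C)C(=O)c1cccnc1NCCCN1CCN(c2ccccc2C(F)(F)F)CC1`: trifluoromethyl in place of cyclopropylmethoxy on an aromatic carbon. No comparable single change has been measured here, so the size of the step is open. Compound 4 is expected to lose some ground, with the step of a 2.5-fold higher number from compound 3 to compound 4 (0.40 log units; beyond the scatter) rated as modest but likely beyond the scatter. The estimate for compound 4 is 25 nM, in the range 8 nM to 80 nM.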

Compound 4, dissociation constant: 316 nM
For compound 4 the middle estimate is 13-fold (1.10 log units) below the measured one; measured number outside the range, above it.
By their numbers in this assay, from the lowest: compound 3; then compounds 1 and 2 (each within the scatter of the next); then compound 4.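

In this assay, trifluoromethyl in place of cyclopropylmethoxy on this aromatic carbon, ortho to a large group, gives a 32-fold higher number from compound 3 to compound 4 (1.50 log units; beyond the scatter). For the compounds shown here, this is the only single change that can be read here, and it shows that the group at this position can move the number by a large margin. Nothing measured here accounts for the size of this step. The step removes the oxygen and the three-membered ring together, so it leaves open which of them matters. A cyclopropyl group attached directly to the aromatic carbon, or a butoxy chain or chlorine at that position, would test this further.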